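The compounds below may be only part of what the source reports. "The series", "measured", "known", "first", "only" and "open" are said of these compounds alone.

Compound 3 `CN1CCN(CCCC(=O)OC2CC3(N(C)C)CC(c4ccccc4)C2C(c2ccccc2)C3)CC1` and compound 1 `CN1CCN(CCC(=O)OC2CC3(N(C)C)CC(c4ccccc4)C2C(c2ccccc2)C3)CC1` share one core, and each carries a chain ending in a 4-methylpiperazin-1-yl group. In an ADME assay on L6 cells (Rattus norvegicus) for cytotoxicity (on this read-out higher numbers stand for weaker inhibition and lower numbers for stronger inhibition), compound 3 gives 19900 nM, and compound 1 gives 31100 nM. The change between them, (4-methylpiperazin-1-yl in place of (4-methylpiperazin-1-yl)methyl on a saturated chain carbon, two bonds along the chain from a carbonyl carbon), made a step of a 1.6-fold higher number from compound 3 to compound 1 (0.19 log units; within the scatter).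

Compound 2 `CN1CCN(CCCN2CCC3(N4CCCCC4)CC(c4ccccc4)C2C(c2ccccc2)C3)CC1` and compound 4 `CN1CCN(CCN2CCC3(N4CCCCC4)CC(c4ccccc4)C2C(c2ccccc2)C3)CC1` rest on another core; the difference between the two cores is not broken down here. In this assay compound 2 gives 62500 nM. From compound 2 to compound 4 the change is 4-methylpiperazin-1-yl in place of (4-methylpiperazin-1-yl)methyl on a saturated chain carbon, two bonds along the chain from an amine nitrogen in a ring. It is the same kind of change as the earlier one, but the place differs: two bonds along the chain from an amine nitrogen in a ring, not from a carbonyl carbon.

Because the step of a 1.6-fold higher number from compound 3 to compound 1 (0.19 log units; within the scatter) was small, the expected step is a 1.4-fold higher number from compound 2 to compound 4 (0.13 log units; within the scatter). Compound 4 is therefore estimated at 85000 nM, expected between 35000 nM and 200000 nM.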

Compound 4, half-maximal inhibitory concentration: 127000 nM
Compound 4: middle estimate off by 1.5-fold (0.17 log units), on the low side; the range from low to high includes it.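

Going from the 3-(4-methylpiperazin-1-yl)propyl chain to the 2-(4-methylpiperazin-1-yl)ethyl chain gives a 2.0-fold higher number from compound 2 to compound 4 (0.31 log units; beyond the scatter) in this assay. Set beside the earlier step, the size of this change cannot be told apart on the two cores: the same change on two cores in this assay, a 1.6-fold higher number (0.19 log units; within the scatter) from compound 3 to compound 1 and a 2.0-fold higher number (0.31 log units; beyond the scatter) from compound 2 to compound 4, 1.3-fold (0.11 log units) apart, within the scatter of two such steps

Within the data shown here, this rests on only two pairs, and one of the two steps lies within the scatter on its own. It therefore does not show that this change will raise the number on every core in the series, and it does not explain the steps.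

Still open, going by these compounds, is how a longer chain would read in this assay. So is a morpholine ring in place of the 4-methylpiperazin-1-yl group.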